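Ring methyl removed: cytotoxicity outlook for compound 3

A few compounds are considered here, and "the series" means these few. Any claim that something is new, unique, unknown or untested is made for them only; others in the source may bear on it.

Among the compounds with values here, compound 1 `Cc1ccnc(NC(=O)c2ccc(F)c(F)c2C)c1` gives 223000 nM in an ADME assay on L6 cells (Rattus norvegicus) for cytotoxicity, read by resazurin assay, with a stated time of 70 h (on this read-out lower numbers stand for stronger inhibition and higher numbers for weaker inhibition), the highest of the two numbers measured so far. Compound 2 `Cc1ccnc(NC(=O)c2ccccc2C)c1` gives 146000 nM in this assay, a value within the scatter of compound 1, so no order between the two is claimed. Compound 3 `Cc1c(C(=O)Nc2ccccn2)ccc(F)c1F` is not yet measured; it differs from compound 1 by hydrogen in place of methyl on an aromatic carbon. Within the data shown here, no measured pair anchors this change, so no shift beyond the scatter is expected in this assay. Compound 3 is expected to give about 200000 nM, within 80000 nM to 500000 nM. The estimated step is a 1.1-fold lower number from compound 1 to compound 3 (0.05 log units; within the scatter).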

Compound 3, half-maximal inhibitory concentration: 308000 nM
Beside the measured number, compound 3's estimate is 1.5-fold (0.19 log units) below it; measured number inside the range.
By their numbers in this assay, from the lowest: compounds 2, 1 and 3 (each within the scatter of the next, the first and the last beyond it).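

Within the data shown here, the step at this position (a 1.4-fold higher number from compound 1 to compound 3 (0.14 log units; within the scatter)) is the first measured change and stays within the scatter in this assay. For this one pair, hydrogen in place of methyl on an aromatic carbon, opposite the ring nitrogen, gives no distinguishable shift. No measured evidence explains the result.

From the compounds shown here alone, whether an amine or a carboxylic acid on the same carbon would move the number beyond the scatter remains open. Also open, going by these compounds, is whether the same change would behave alike on the core of compound 2.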